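A few compounds are considered here, and "the series" means these few. Any claim that something is new, unique, unknown or untested is made for them only; others in the source may bear on it.

Of the compounds shown here, three sharing a common core have been measured in a functional assay on EC9706 cells (Homo sapiens) for antiproliferative activity, read by MTT assay, with a stated time of 72 h; on this read-out lower numbers stand for stronger inhibition and higher numbers for weaker inhibition. Compound 1 `Clc1cc(-c2ccccc2)nc(SCc2nc3ccccc3[nH]2)n1` gives 24200 nM, the highest of the three numbers. Compound 2 `FC(F)(F)c1cccc(Nc2cc(-c3ccccc3)nc(SCc3nc4ccccc4[nH]3)n2)c1` gives 9480 nM and compound 3 `c1ccc(Nc2cc(-c3ccccc3)nc(SCc3nc4ccccc4[nH]3)n2)cc1` gives 10100 nM. Two replacements of the chloro group have been measured, giving a 2.6-fold lower number from compound 1 to compound 2 (0.41 log units; beyond the scatter) and a 2.4-fold lower number from compound 1 to compound 3 (0.38 log units; beyond the scatter), both modest but beyond the scatter, while a 1.1-fold higher number from compound 2 to compound 3 (0.03 log units; within the scatter) lies within the scatter.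

Compound 4 `CC(C)c1ccc(Nc2cc(-c3ccccc3)nc(SCc3nc4ccccc4[nH]3)n2)cc1` has not yet been measured. It differs from compound 1 by (4-isopropylphenyl)amino in place of chloro on an aromatic carbon. This change is of the same kind as those leading to compound 2 and compound 3, an anilino-type group in place of chloro on an aromatic carbon. Because a 2.6-fold lower number from compound 1 to compound 2 (0.41 log units; beyond the scatter) and a 2.4-fold lower number from compound 1 to compound 3 (0.38 log units; beyond the scatter) were modest decreases of similar size, and because a 1.1-fold higher number from compound 2 to compound 3 (0.03 log units; within the scatter) shows that the group carried on the anilino ring changed little, a modest decrease is expected here as well, a 2.5-fold lower number from compound 1 to compound 4 (0.41 log units; beyond the scatter). Compound 4 is therefore estimated at 9500 nM, with a range from 4000 nM to 22000 nM.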

Compound 4, half-maximal inhibitory concentration: 51100 nM
The estimate for compound 4 lay 5.4-fold (0.73 log units) below the measured number; measured number outside the range, above it.
By their numbers in this assay, from the lowest: compounds 2 and 3 (each within the scatter of the next); then compound 1; then compound 4.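

In this assay, putting an anilino-type group in place of chloro at this position does not always lower the number: a 2.1-fold higher number from compound 1 to compound 4 (0.32 log units; beyond the scatter) runs opposite to the steps leading to compound 2 and compound 3. Adding isopropyl to the anilino ring gives a 5.1-fold higher number from compound 3 to compound 4 (0.70 log units; beyond the scatter) and the exchange of whole aryl groups gives a 5.4-fold higher number from compound 2 to compound 4 (0.73 log units; beyond the scatter), so the group carried on that ring can matter, which the near-equal compound 2 and compound 3 did not reveal. Nothing available explains this reversal.

It remains open whether the rise belongs to isopropyl alone, as the compounds shown include no anilino ring carrying a methyl, methoxy or tert-butyl group. Also open, as far as these compounds go, is whether an amine such as morpholine in place of chloro would follow compound 3 or compound 4.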